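The source may hold more compounds than are shown below. What is called first, only, known or untested is meant among the compounds shown, and "the series" means these compounds.

Measured so far:
- compound 1 `CC(C)[C@H](C(=O)Nc1ncns1)c1ccc(Cl)cc1`: 2000 nM in a functional assay on CHO cells for agonist activity at Free fatty acid receptor 2 (Homo sapiens), read by cAMP accumulation; on this read-out higher numbers stand for weaker inhibition and lower numbers for stronger inhibition
- compound 2 `C[C@H](C(=O)Nc1nccs1)c1ccc(Cl)cc1`: 46000 nM in this assay

Compound 2 gives the highest of the two numbers in this assay; compound 1 gives a far lower number, and the gap between the two is beyond the usual scatter. Compound 3 `COCC[C@H](C(=O)Nc1nccs1)c1ccc(Cl)cc1` differs from compound 2 by methoxymethyl in place of hydrogen on a saturated chain carbon, two bonds along the chain from an aromatic carbon and a carbonyl carbon. Among the measured compounds shown here, no measured step of this kind exists. In this assay the number for compound 3 is expected to drop, by a 5.8-fold lower number from compound 2 to compound 3 (0.76 log units; beyond the scatter), because compound 1, which also carries a larger group on that chain carbon, gives 2000 nM. Compound 3 is estimated at 8000 nM, within 2500 nM to 25000 nM.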

Compound 3, half-maximal inhibitory concentration: 170000 nM
Estimate against measurement, compound 3: 21-fold (1.33 log units) below; the measured number lies above the stated range.
By their numbers in this assay, from the lowest: compound 1; then compound 2; then compound 3.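

In this assay, the step at this chain carbon reads a 3.7-fold higher number from compound 2 to compound 3 (0.57 log units; beyond the scatter) and so points to weaker inhibition with methoxymethyl in place of hydrogen. On the core of compound 2, a larger group at this carbon therefore does not by itself bring a lower number. No measurement at hand explains the rise.

Compound 1 differs from compound 2 in more than one place, so its lower number cannot be assigned to the chain carbon alone. Open too, as far as these compounds go, is how a plain longer chain, an amine or a carboxylic acid would read at this carbon.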